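The compounds below may be only part of what the source reports. "The series", "measured", "known", "first", "only" and "open" are said of these compounds alone.

Measured in a functional assay on HeLa cells (Homo sapiens) for antiproliferative activity, read by MTT assay, with a stated time of 72 h; a lower number here means a stronger inhibitor, a higher number a weaker inhibitor:
- compound 1 (`COc1cc(-c2ncnn2-c2cccc(F)c2)cc(OC)c1OC`) gives > 10000 nM (a limit of the assay, not a number)
- compound 2 (`COc1cc(-n2ncnc2-c2ccc(C)cc2)cc(OC)c1OC`) gives 250 nM
- compound 3 (`CCOc1ccc(-c2ncnn2-c2cc(OC)c(OC)c(OC)c2)cc1Cl`) gives 6 nM

Compound 1 has only a limit and no number. Of the two real numbers, compound 2 holds the higher, which makes it the weaker inhibitor of the pair. Compound 3 lies below it by a gap well beyond the scatter.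

The next compound to be tested is compound 4 (`COc1cc(-n2ncnc2-c2ccccc2)cc(OC)c1OC`), which differs from compound 2 by hydrogen in place of methyl on an aromatic carbon and has hydrogen in place of methyl on an aromatic carbon, so that 4-methylphenyl becomes phenyl. Within the data shown here, no measured pair isolates this change, so any expectation is tentative. Compound 2 at 250 nM and compound 3 at 6 nM both carry substituents on this aromatic ring, whereas compound 4 carries none there. A moderate move towards a higher number in this assay is therefore expected, probably beyond the scatter. The estimated change is a 4.8-fold higher number from compound 2 to compound 4 (0.68 log units; beyond the scatter) and points towards weaker inhibition. Compound 4 is expected at about 1200 nM, with an estimated range from 250 nM to 8000 nM.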

Compound 4, half-maximal inhibitory concentration: > 10000 nM
Compound 4 ended at the assay's limit; the forecaster's own chance of this, stated with the estimate: 15%; middle value at least 8.3-fold (0.92 log units) from the limit.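

In this assay, among these compounds, the change from 4-methylphenyl to phenyl is the first single change that can be read, and it gives an at least 40-fold higher number from compound 2 to compound 4 (1.60 log units; beyond the scatter). This shows that the position, on an aromatic carbon para to a large group, is not indifferent in this series: one methyl, a single heavy atom with no hydrogen-bond donor or acceptor, separates a measured potency from no measured potency. The value of compound 4 is a limit of the assay and not a number, so the step gives only a bound on the size of the change: the limit of > 10000 nM in this assay, at which 2 of the 4 values shown sit.

Going by these compounds, the true size of the step therefore stays unknown, and this single pair cannot say whether the methyl itself matters or whether any group at this place would serve as well. Whether an amine, a hydroxyl group or a longer chain such as propyl in place of the methyl would keep, raise or lose the activity in this assay also remains open, as does the question of why the methyl has so large an effect here.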